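Replacing the dimethylphenyl amide in an orexin-1 antagonist series

A few compounds are considered here, and "the series" means these few. Any claim that something is new, unique, unknown or untested is made for them only; others in the source may bear on it.

Measured compounds:
compound 1 `Cc1cccc(C)c1NC(=O)CSc1nnc(-c2ccoc2C)n1Cc1ccco1`: > 15800 nM
compound 2 `Cc1occc1-c1nnc(SCC(=O)Nc2ccc(F)c(Cl)c2)n1Cc1ccco1`: 1000 nM

In a functional assay on CHO cells for antagonist activity at Orexin/Hypocretin receptor type 1 (Homo sapiens), read by FLIPR and calcium flux (a higher number here means a weaker inhibitor, a lower number a stronger inhibitor), compound 1 gives > 15800 nM, and this value is a limit of the assay rather than a number (the limit of > 15800 nM in this assay, at which 1 of the 2 values shown sits). Compound 2 gives 1000 nM in this assay. Within the data shown here, the single measured step, an at least 15-fold lower number from compound 1 to compound 2 (1.19 log units; beyond the scatter), is large. Compound 3 `Cc1occc1-c1nnc(SCC(=O)Nc2cccc(F)c2)n1Cc1ccco1` differs from compound 1 by 3-fluorophenyl in place of 2,6-dimethylphenyl on an amide-type nitrogen. This change resembles that step, since both remove the 2,6-dimethylphenyl, so a gain in this assay is expected for compound 3, estimated as an at least 5.2-fold lower number from compound 1 to compound 3 (0.72 log units; beyond the scatter). Compound 3 is therefore expected to give about 3000 nM in this assay, in the range 800 nM to 15800 nM.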

Compound 3, inhibition constant: > 15800 nM
Compound 3 gave a limit, no number (the forecaster's own chance of this, stated with the estimate: 30%); at least 5.2-fold (0.72 log units) between middle value and limit.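

Setting 3-fluorophenyl in place of 3-chloro-4-fluorophenyl on the amide-type nitrogen gives an at least 15-fold higher number from compound 2 to compound 3 (1.19 log units; beyond the scatter) and this shows that losing the 2,6-dimethylphenyl is not enough on its own: the group that enters decides the outcome. Compound 3 gives > 15800 nM in this assay and this is a limit, not a number, so the step from compound 1 cannot be read: the limit of > 15800 nM in this assay, at which 2 of the 3 values shown sit.

Which part of the 3-chloro-4-fluorophenyl carries the gain stays open. A 3-chlorophenyl or a 4-fluorophenyl on this nitrogen would separate the two halogens.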